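This account rests on a few compounds, and the source may have more. Where it says the series, first, only, none or still open, it means among the compounds named here.

Compounds measured in an ADME assay on Vero cells (Chlorocebus sabaeus) for cytotoxicity, with a stated time of 72 h; on this read-out lower numbers stand for stronger inhibition and higher numbers for weaker inhibition:
Compound 1, `CCOC(=O)c1cc(-c2cccc(OCc3ccccc3)c2)on1`: > 128000 nM, a limit of the assay rather than a number.
Compound 2, `CCOC(=O)c1cc(-c2cccc(OCc3cccc(OC(F)(F)F)c3)c2)on1`: 101000 nM.
Compound 3, `CCOC(=O)c1cc(-c2cccc(OCc3cccc([N+](=O)[O-])c3)c2)on1`: > 128000 nM, again a limit of the assay.

Compound 3 stands at the limit of > 128000 nM in this assay, at which 2 of the 3 values shown sit. All three compounds share one core and differ only in the group carried on the outer benzene ring of the benzyl ether. The step of an at least 1.2-fold lower number from compound 1 to compound 2 (0.10 log units; that floor lies within the scatter) gives a floor that lies within the scatter. The step of an at least 1.2-fold higher number from compound 2 to compound 3 (0.10 log units; that floor lies within the scatter) likewise gives only a floor within the scatter. The step that the two limits leave unreadable from compound 1 to compound 3 cannot be read, since both ends are limits. Taken together, the measured steps show no movement beyond the scatter anywhere in this small set.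

Compound 4, `CCOC(=O)c1cc(-c2cccc(OCc3cccc(OC)c3)c2)on1`, has not yet been measured. Its change from compound 3 is methoxy in place of nitro on an aromatic carbon. The two readable steps at the same place, from compound 1 to compound 2 and from compound 2 to compound 3, both stayed within the scatter, so no step beyond the scatter is expected here either; the expected step is an at least 1.0-fold lower number from compound 3 to compound 4 (0.02 log units; that floor lies within the scatter). Compound 4 is therefore estimated at 120000 nM in this assay, with a range from 70000 nM to 200000 nM, and a fair chance that only a limit is reported.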

Compound 4, half-maximal inhibitory concentration: > 128000 nM
Compound 4: a limit, no number (the forecaster's own chance of this, stated with the estimate: 60%); at least 1.0-fold (0.02 log units) between middle value and limit.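

In this assay, compound 4 gives only a limit and no number, so methoxy on this aromatic carbon joins hydrogen in compound 1 and nitro in compound 3 at the same ceiling: the limit of > 128000 nM in this assay, at which 3 of the 4 values shown sit. Among the compounds shown here, the one readable step, an at least 1.2-fold higher number from compound 2 to compound 4 (0.10 log units; that floor lies within the scatter), gives only a floor that lies within the scatter, and the steps to compound 4 from compound 1 and from compound 3 cannot be read. For the compounds shown here, a third kind of group at this place therefore adds no separation that can be read, and compound 2, with trifluoromethoxy, remains the only compound here with a number, though that number does not stand clearly apart from the limits.

On these data alone, it remains open whether any group at this place can move the value beyond the scatter, and how far above the limit compound 1, compound 3 and compound 4 truly lie. An amine or a carboxylic acid on this aromatic carbon, or a longer chain in place of the methyl of the methoxy, might or might not bring a readable number.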